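This account rests on a few compounds, and the source may have more. Where it says the series, first, only, none or still open, it means among the compounds named here.

Working notes on the series. Compound 2 `CC1CCN(c2c(S(=O)(=O)c3cc(F)cc(F)c3)cnc3cc(F)ccc23)CC1` carries a methyl on the saturated ring in place of the methoxymethyl of compound 1 `COCC1CCN(c2c(S(=O)(=O)c3cc(F)cc(F)c3)cnc3cc(F)ccc23)CC1`; in an assay on isolated protein for displacement of a labelled ligand from metabotropic glutamate receptor 5 (Homo sapiens), with a stated time of 60 min, tested at 1 uM (a higher number here means more inhibition at the concentration tested (going by the name of the read-out), a lower number less inhibition), compound 2 gives 77%, while compound 1 gives 83%, a move of a number 6 percentage points lower from compound 1 to compound 2 (within the scatter). Compound 3 `CC1CCN(c2c(S(=O)(=O)c3ccc(F)cc3)cnc3cc(Cl)ccc23)CC1` differs from compound 2 in two places; in this assay compound 3 gives 91%. Among the three numbers the one for compound 2 sits lowest, with the gap to compound 1 inside the scatter and the gap to compound 3 beyond it.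

Compound 4 `Cc1cc(C)cc(S(=O)(=O)c2cnc3cc(F)ccc3c2N2CCC(C)CC2)c1` is the next member: 3,5-dimethylphenyl in place of 3,5-difluorophenyl on a sulfonyl sulfur. Among the compounds with values here, no measured step touches the group on the sulfonyl sulfur; the single step measured so far, the one from compound 1 to compound 2, concerns the saturated ring and was within the scatter. The difference between compound 2 and compound 3 involves two changes at once and does not isolate this one. With nothing to anchor a direction, the expected step in this assay is a number 3 percentage points lower from compound 2 to compound 4 (within the scatter), none beyond the scatter. Compound 4 is therefore estimated at 74%, in the range 55% to 90%.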

Compound 4, a percentage reported as inhibition, at one concentration (the size of the read-out at that concentration, not a potency): 80%
Estimate against measurement, compound 4: 6 percentage points below; the measured number falls inside the stated range.
By their numbers in this assay, from the lowest: compounds 2, 4, 1 and 3 (each within the scatter of the next, the first and the last beyond it).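

The group on the sulfonyl sulfur now has its first measured step: in this assay, 3,5-dimethylphenyl in place of 3,5-difluorophenyl gives a number 3 percentage points higher from compound 2 to compound 4 (within the scatter). With the rest of the structure held fixed, this exchange of two fluorines for two methyl groups stays within the scatter, so the read-out at this one tested concentration does not separate the two groups. Nothing measured here offers an explanation for this result.

Still open, from the compounds shown here alone, is whether a different group on the phenyl ring at this position, such as an amine or a carboxylic acid, would give a step beyond the scatter. The two changes that separate compound 3 from compound 2 also remain unresolved, and neither can be read alone.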